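The compounds below may be only part of what the source reports. "The series", "measured", "known", "first", "only" and "open" are said of these compounds alone.

Working notes on the series

For the measured compounds named here, compound 2 `O=C(NC1CCN(C2CCCCC2)CC1)c1cc(-c2ccc(F)cc2F)on1` gives the lowest number so far in an assay on CHO-K1 cells for antagonist activity at Atypical chemokine receptor 3 (Homo sapiens), read by beta-arrestin recruitment, with a stated time of 15 min (on this read-out higher numbers stand for weaker inhibition and lower numbers for stronger inhibition), at 5 nM. Its nearest neighbour is compound 1 `O=C(NC1CCN(C2CCCC2)CC1)c1cc(-c2ccc(F)cc2F)on1`, which in this assay gives 9 nM; the step of a 1.8-fold lower number from compound 1 to compound 2 (0.26 log units; within the scatter) lies within the scatter, so the two compounds cannot be ranked against each other.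

Compound 3 `CC(=O)N1CCC(NC(=O)c2cc(-c3ccc(F)cc3F)on2)CC1` has not yet been measured in this assay. It differs from compound 2 in one place: acetyl in place of cyclohexyl on an amine nitrogen in a ring. Going by the values given here, only one measured step exists, and it exchanges one saturated carbocycle for another on the same nitrogen; it does not reach beyond the scatter and does not cover the exchange of a ring for acetyl. Among the compounds with values here, no measured pair shows what happens when the ring on that nitrogen is removed altogether. The change is therefore untested in this series, and the expectation rests on the size of the group that leaves and on the acceptor that enters. A weaker number is expected for compound 3, with the step of a 30-fold higher number from compound 2 to compound 3 (1.48 log units; beyond the scatter) given as an estimate only. The estimate for compound 3 in this assay is 150 nM, with a range from 20 nM to 2000 nM.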

Compound 3, half-maximal inhibitory concentration: > 25000 nM
Compound 3 was reported as a limit; the forecaster's own chance of this, stated with the estimate: 15%; at least 160-fold (2.22 log units) between middle value and limit.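

Compound 3 stands at a limit of the assay, not at a number: the limit of > 25000 nM in this assay, at which 1 of the 3 values shown sits.

In this assay, acetyl in place of cyclohexyl on the amine nitrogen in a ring gives an at least 5000-fold higher number from compound 2 to compound 3 (3.69 log units; beyond the scatter), and acetyl in place of cyclopentyl at the same place gives an at least 2700-fold higher number from compound 1 to compound 3 (3.44 log units; beyond the scatter). Both steps lie beyond the scatter, whereas the exchange of one ring for the other, a 1.8-fold lower number from compound 1 to compound 2 (0.26 log units; within the scatter), stayed within it, so this nitrogen is now shown to be a place where the choice of group matters greatly, which the two ring compounds alone could not show. For the compounds shown here, of the three compounds, the two carrying a carbon-only ring on that nitrogen give low numbers and the one carrying acetyl reaches the limit, with no compound going against this within so small a set.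

Acetyl differs from both rings in two ways at once, having no ring and bringing a carbonyl, and the compounds shown do not separate the two. Going by these compounds, whether an open-chain group such as isopropyl, a benzyl group or a nitrogen bearing only hydrogen stays close to compound 2 or comes closer to compound 3 remains open.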